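Hydrazone aryl exchange on a shared triazine sulfonamide core

The compounds below may be only part of what the source reports. "The series", "measured", "known", "first", "only" and "open" are said of these compounds alone.

Measured so far in a functional assay on ACHN cells (Homo sapiens) for inhibition, read by sulforhodamine B assay, with a stated time of 48 h; a lower number here means a stronger inhibitor of growth, a higher number a weaker inhibitor of growth:
compound 1 `NS(=O)(=O)c1ccc(Nc2nc(N/N=C/c3ccc(C(F)(F)F)cc3)nc(Nc3ccccc3)n2)cc1`: 2680 nM
compound 2 `Cc1nn(-c2ccccc2)cc1/C=N/Nc1nc(Nc2ccccc2)nc(Nc2ccc(S(N)(=O)=O)cc2)n1`: 1900 nM

Among the compounds with values here, compound 2 stands lowest of the two numbers in this assay, yet the only step, a 1.4-fold lower number from compound 1 to compound 2 (0.15 log units; within the scatter), lies within the scatter, so the two compounds cannot be ordered.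

Compound 3 `NS(=O)(=O)c1ccc(Nc2nc(N/N=C/c3ccccn3)nc(Nc3ccccc3)n2)cc1` differs from compound 2 by pyridin-2-yl in place of 3-methyl-1-phenyl-1H-pyrazol-4-yl on a carbon with a double bond to nitrogen. Within the data shown here, the single step that bears on this position, a 1.4-fold lower number from compound 1 to compound 2 (0.15 log units; within the scatter), exchanged the group on the same carbon and moved the number little. No step beyond the scatter is therefore expected in this assay for this further exchange.

For compound 3 the estimate is 2500 nM, with a range from 900 nM to 7000 nM, which means an expected 1.3-fold higher number from compound 2 to compound 3 (0.12 log units; within the scatter).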

Compound 3, concentration for 50% growth inhibition: 1120 nM
Compound 3: the middle estimate sits 2.2-fold (0.35 log units) above what was measured; the measured number falls inside the stated range.
By their numbers in this assay, from the lowest: compounds 3, 2 and 1 (each within the scatter of the next, the first and the last beyond it).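

In this assay, within the data shown here, pyridin-2-yl gives the first exchange on this carbon with a double bond to nitrogen to pass the scatter, a modest step in place of 4-(trifluoromethyl)phenyl (a 2.4-fold lower number from compound 1 to compound 3 (0.38 log units; beyond the scatter)). Against 3-methyl-1-phenyl-1H-pyrazol-4-yl the same group cannot be ordered (a 1.7-fold lower number from compound 2 to compound 3 (0.23 log units; within the scatter)), so going from 12 heavy atoms to 6 here gives no resolved difference. No measured evidence accounts for either step.

Open, from the compounds shown here alone, is whether pyridin-3-yl, or an aryl group carrying an amine or a carboxylic acid, would extend the step from 4-(trifluoromethyl)phenyl.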